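Chloro in place of fluoro: an expected small step

The source may report more compounds than this note shows. Statements on the series, on what has been measured and on what is new or still open speak of the compounds shown alone.

Compound 1 `O=C(c1cccnc1)c1cc(F)ccc1O` is one of two compounds already tested in a functional assay on PC-3 cells (Homo sapiens) for cytotoxicity, read by sulforhodamine B assay, with a stated time of 48 h; on this read-out higher numbers stand for weaker inhibition and lower numbers for stronger inhibition. In this assay, among the measured compounds shown here, compound 1 gives 11800 nM, the only plain number among the two values shown. Compound 2 `C=CCOc1c(Cl)cccc1C(=O)c1cccnc1` gives > 100000 nM, which is a limit of the assay and not a number (the limit of > 100000 nM in this assay, at which 1 of the 2 values shown sits). Compound 3 `O=C(c1cccnc1)c1cc(Cl)ccc1O` is not yet measured; it differs from compound 1 by chloro in place of fluoro on an aromatic carbon. For the measured compounds named here, no measured pair shows how such a swap acts here, so the step of a 1.2-fold lower number from compound 1 to compound 3 (0.07 log units; within the scatter) is expected to stay within the scatter. Compound 3 is estimated at 10000 nM, ranging from 4000 nM to 25000 nM.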

Compound 3, half-maximal inhibitory concentration: 24800 nM
The estimate for compound 3 lay 2.5-fold (0.39 log units) below the measured number, and the stated range covers the measured number.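

Among the compounds shown here, at this position, para to a hydroxy group, chloro in place of fluoro is the first swap in this assay that can be read directly, and it gives a 2.1-fold higher number from compound 1 to compound 3 (0.32 log units; beyond the scatter). For the compounds shown here, the change is modest but real: of these two halogens, fluoro goes with the stronger inhibition here, which no earlier pair could show. Going by these compounds alone, nothing measured so far explains why the number moves this way.

On these data alone, whether a bromo or a methyl group at this position would continue this trend or reverse it stays open. So does the effect of an amine there.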